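A few compounds are considered here, and "the series" means these few. Any claim that something is new, unique, unknown or untested is made for them only; others in the source may bear on it.

Of the compounds shown here, two have been tested in a functional assay on the whole organism (strain albino) for inhibition, with Rattus norvegicus as the target, read by paw edema, with stated times of 30 min and 4 h, at a dose of 100 mg/kg by the oral route; a lower number here means less inhibition, a higher number more inhibition at the dose given (going by the name of the read-out). Compound 1, `O=C(CO[N+](=O)[O-])Nc1ccc(C(=O)/C=C/c2ccco2)cc1`, carries a furan-2-yl group on the enone chain and an unbranched nitrooxy acetamide; in this assay compound 1 gives 40%. Compound 2, `CC(O[N+](=O)[O-])C(=O)Nc1ccc(C(=O)/C=C/c2ccc(Cl)cc2)cc1`, carries a 4-chlorophenyl group on the same chain together with a methyl-branched nitrooxy propanamide; in this assay compound 2 gives 61%. Of the two numbers in hand, compound 2 stands highest, and its margin over compound 1 lies beyond the usual scatter. The two compounds differ in two places, so their values alone do not say which change carries the difference.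

Compound 3, `CC(O[N+](=O)[O-])C(=O)Nc1ccc(C(=O)/C=C/c2ccco2)cc1`, keeps the branched amide of compound 2 and differs from it in one place: furan-2-yl in place of 4-chlorophenyl on a double-bonded chain carbon bound to a double-bonded chain carbon. Because compound 1, which carries the same furan-2-yl group, gives 40%, a downward step from compound 2 is expected, though of moderate size, since the amide of compound 3 matches that of compound 2. The expected step of a number 13 percentage points lower from compound 2 to compound 3 (beyond the scatter) would place compound 3 between the two measured values. Compound 3 is thus estimated at 48%, within a range from 32% to 64%.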

Compound 3, a percentage reported as inhibition, in the whole organism at one dose (the size of the read-out at that dose, not a potency): 49%
Beside the measured number, compound 3's estimate is 1 percentage points below it; the measured number falls inside the stated range.
By their numbers in this assay, from the lowest: compounds 1 and 3 (each within the scatter of the next); then compound 2.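

With the branched amide held constant, furan-2-yl in place of 4-chlorophenyl on a double-bonded chain carbon bound to a double-bonded chain carbon gives in this assay a number 12 percentage points lower from compound 2 to compound 3 (beyond the scatter) and so shows, as the first two compounds could not, that the exchange at this place alone moves the number. With furan-2-yl held constant, methyl in place of hydrogen on a saturated chain carbon bound to a carbonyl carbon and an oxygen on an unsaturated carbon gives a number 9 percentage points higher from compound 1 to compound 3 (within the scatter) and thus does not set the branched amide apart from the unbranched one in this pair. Nothing available explains why the group on the enone chain matters here while the methyl cannot be told apart from hydrogen.

Going by these compounds, the exchange replaces a ring and removes a chlorine at once, so it remains open whether an unsubstituted phenyl or a thiophen-2-yl group at this place would read closer to compound 2 or to compound 3. On these data alone, it also remains open whether the methyl would read the same way with 4-chlorophenyl on the chain, or whether an ethyl group in its place would give a step beyond the scatter.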